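This account rests on a few compounds, and the source may have more. Where it says the series, first, only, none or still open, it means among the compounds named here.

Compound 1 `Cc1nn(C)c2c1C(c1ccncc1)C(C#N)=C(N)O2` gives 4100 nM in a functional assay on NCI-H2122 cells (Homo sapiens) for inhibition, read by microscopy, with a stated time of 10 days (on this read-out lower numbers stand for stronger inhibition and higher numbers for weaker inhibition), the lowest of the two numbers shown, although the gap to compound 2 lies within the scatter. For the measured compounds named here, compound 2 `Cn1nc(-c2ccccc2)c2c1OC(N)=C(C#N)C2c1ccncc1` gives 5200 nM in this assay, and the single measured step, a 1.3-fold higher number from compound 1 to compound 2 (0.10 log units; within the scatter), concerns the aromatic carbon of the shared core rather than the saturated ring carbon. Compound 3 `Cc1nn(C)c2c1C(c1cccc(Br)n1)C(C#N)=C(N)O2` differs from compound 1 by 6-bromopyridin-2-yl in place of pyridin-4-yl on a saturated ring carbon. Going by the values given here, no measured step touches this position, so the data give no direction for the change; the only step available did not move the number beyond the scatter. Compound 3 is therefore expected to sit close to compound 1, with a 1.0-fold lower number from compound 1 to compound 3 (0.01 log units; within the scatter) as the estimated step, and a wide range to reflect the lack of a comparable measurement. The estimate for compound 3 in this assay is 4000 nM, between 1000 nM and 16000 nM.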

Compound 3, half-maximal inhibitory concentration: 2400 nM
Estimate against measurement, compound 3: 1.7-fold (0.22 log units) above; low and high end bracket the measured number.
By their numbers in this assay, from the lowest: compounds 3, 1 and 2 (each within the scatter of the next, the first and the last beyond it).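

In this assay, the saturated ring carbon now has a measured step of its own: a 1.7-fold lower number from compound 1 to compound 3 (0.23 log units; within the scatter). For the compounds shown here, replacing pyridin-4-yl with 6-bromopyridin-2-yl changes the aromatic group and adds a bromine in a single exchange, yet the number stays within the scatter, so this change brings no loss of inhibition beyond it, and the single step cannot separate the contribution of the bromine from that of the pyridine attachment. No available evidence bears on this result.

As far as these compounds go, whether a pyridine carrying an amine or a carboxylic acid in place of the bromine, or a non-aromatic cyclohexyl group on this carbon, would move the number beyond the scatter remains open. So does whether 6-bromopyridin-2-yl would give a similar step alongside the phenyl group of compound 2.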